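Swapping Chloro for Bromo on One Aromatic Ring

The source may report more compounds than this note shows. Statements on the series, on what has been measured and on what is new or still open speak of the compounds shown alone.

Going by the values given here, only two compounds have numbers so far. In a functional assay on HepG2 cells (Homo sapiens) for antiproliferative activity, read by sulforhodamine B assay, with a stated time of 48 h (on this read-out higher numbers stand for weaker inhibition and lower numbers for stronger inhibition), compound 1 (`COc1cccc(C2=NN(c3ccccc3)C(c3ccc(Br)cc3)C2O)c1`) gives 9.9 nM and compound 2 (`COc1cccc(C2=NNC(c3ccc(Cl)cc3)C2O)c1`) gives 35.3 nM as its result. Compound 2 therefore holds the higher of the two numbers, which means the weaker inhibition, and the gap between them is larger than repeated measurements would normally produce.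

The next compound to be tested is compound 3 (`COc1cccc(C2=NNC(c3ccc(Br)cc3)C2O)c1`), which differs from compound 2 in a single place (bromo in place of chloro on an aromatic carbon). The swap turns 4-chlorophenyl into 4-bromophenyl, and it sits para to a large group. Among the compounds with values here, no measured pair shows this change on its own, so the data give no direct size for it. Compound 2, at 35.3 nM, is the closest measured relative and serves as the starting point. The expected 1.2-fold lower number from compound 2 to compound 3 (0.07 log units; within the scatter) is small, with no shift beyond the scatter anticipated in this assay for this swap. Compound 3 is expected to come in at 30 nM with an estimated range from 12 nM to 75 nM once it is measured.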

Compound 3, half-maximal inhibitory concentration: 43 nM
For compound 3 the middle estimate is 1.4-fold (0.16 log units) below the measured one; measured number inside the range.
By their numbers in this assay, from the lowest: compound 1; then compounds 2 and 3 (each within the scatter of the next).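

In this assay the change from 4-chlorophenyl to 4-bromophenyl now has a direct measure, a 1.2-fold higher number from compound 2 to compound 3 (0.09 log units; within the scatter), so on this aromatic carbon, para to a large group, chloro and bromo cannot be told apart. Going by these compounds alone, compound 3 also supplies the first comparison that differs in one place only and lies beyond the scatter, a 4.3-fold higher number from compound 1 to compound 3 (0.64 log units; beyond the scatter), with hydrogen in place of phenyl on the amine nitrogen in the ring, which makes this nitrogen, and not the halogen, the site where a change has so far registered in the numbers. Nothing measured here speaks to why either step has the size it does.

On these data alone, only hydrogen and phenyl appear on that nitrogen, so it remains open whether a smaller carbon group such as methyl, or a substituted phenyl, would land nearer compound 1 or compound 3. As far as these compounds go, it is also open whether a group unlike the two halogens, such as methoxy or an amine, would be tolerated as evenly on the aromatic carbon, and whether chloro and bromo would still match with phenyl on the nitrogen.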